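Triazolyl for thiadiazolyl on the sulfur: expecting compound 4

The source may hold more compounds than are shown below. What is called first, only, known or untested is meant among the compounds shown, and "the series" means these compounds.

Three members of the series have been tested in a functional assay on HCT-116 cells (Homo sapiens) for antiproliferative activity, read by MTT assay, with a stated time of 48 h; a higher number here means a weaker inhibitor, a lower number a stronger inhibitor. Compound 1 `COc1cccc(C(=O)Nc2cc(Sc3ncn[nH]3)c(O)c3ccccc23)c1` gives > 100000 nM, which is a limit of the assay and not a number. Compound 3 `O=C(/C=C/c1ccc([N+](=O)[O-])cc1)Nc1cc(Sc2ncn[nH]2)c(O)c2ccccc12` likewise gives > 100000 nM, again only a limit. Compound 2 `Cc1nnc(Sc2cc(NC(=O)c3ccc(Cl)cc3)c3ccccc3c2O)s1` stands at > 100000 nM, also a limit. The shown set thus rests entirely on (the limit of > 100000 nM in this assay, at which 3 of the 3 values shown sit); no step between measured compounds can be read, and compound 2 cannot be ordered against any other member.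

Compound 4 `O=C(Nc1cc(Sc2ncn[nH]2)c(O)c2ccccc12)c1ccc(Cl)cc1` is not yet measured. It differs from compound 2 in one place: 1H-1,2,4-triazol-5-yl in place of 5-methyl-1,3,4-thiadiazol-2-yl on a sulfur. Everything else in the two structures is unchanged. Compound 1 and compound 3 already carry the 1H-1,2,4-triazol-5-yl on the sulfur and both sit at the limit, so the change itself has shown no move off the limit. No step beyond the scatter is expected in this assay, and the expected change is a number no higher from compound 2 to compound 4 (the limit leaves the size open), with a high chance that only a limit is reported again. Compound 4 is estimated at 100000 nM, within 30000 nM to 300000 nM.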

Compound 4, half-maximal inhibitory concentration: 43300 nM
For compound 4 the middle estimate is 2.3-fold (0.36 log units) above the measured one; the range from low to high includes it.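

In this assay, compound 4 is the only compound shown with a number and not a limit, so 1H-1,2,4-triazol-5-yl on a sulfur is compatible with a measurable value, giving an at least 2.3-fold lower number from compound 2 to compound 4 (0.36 log units; beyond the scatter). That group alone is not enough, since compound 1 carries it too; 4-chlorophenyl in place of 3-methoxyphenyl on a carbonyl carbon gives an at least 2.3-fold lower number from compound 1 to compound 4 (0.36 log units; beyond the scatter). Compound 2 carries the 4-chlorophenyl and compound 1 the triazolyl, so among these compounds a number appears only with the two groups together, and the true sizes of both steps stay open: the limit of > 100000 nM in this assay, at which 3 of the 4 values shown sit.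

Steps among compound 1, compound 2 and compound 3 cannot be read. Still open, as far as these compounds go, is whether an aminophenyl or a carboxyphenyl on the carbonyl carbon, or a longer chain on the sulfur, would lower the number further.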